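Notes on the step from compound 2 to compound 3

A few compounds are considered here, and "the series" means these few. Any claim that something is new, unique, unknown or untested is made for them only; others in the source may bear on it.

compound 1 `CCCCNc1nc(N)nc2ccn(Cc3ccccc3)c12`: > 24000 nM (a limit)
compound 2 `CCCCNc1nc(N)nc2ccn(Cc3nccs3)c12`: > 24000 nM (a limit)

Both entries come from an ADME assay on HEK293 cells (Homo sapiens) for cytotoxicity, read by ATP content, with a stated time of 6 h; a higher number here means that more compound is tolerated, a lower number that less compound is tolerated. Compound 2 gives > 24000 nM, which is a limit and not a number. Its standing in the series is therefore set by the limit of > 24000 nM in this assay, at which 2 of the 2 values shown sit.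

Compound 3 `CCCCNc1nc(N)nc2ccn(Cc3cccc(C)n3)c12` carries 6-methylpyridin-2-yl in place of 1,3-thiazol-2-yl on a saturated chain carbon bound to an aromatic nitrogen.

Going by the values given here, one measured step bears on this place, with 1,3-thiazol-2-yl in place of phenyl: a step that the two limits leave unreadable from compound 1 to compound 2. It gives no size to carry over and no direction, so no step beyond the scatter is expected in this assay.

The step expected on this estimate is a step that the limit leaves unreadable from compound 2 to compound 3. Compound 3 is expected at 30000 nM, with an estimated range of 16000 nM to 50000 nM, and a report as a limit again is the likeliest outcome.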

Compound 3, half-maximal cytotoxic concentration: > 24000 nM
Compound 3: no number, only a limit (the forecaster's own chance of this, stated with the estimate: 85%); the middle value lies beyond the limit too.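

No new step can be read in this assay: compound 1, compound 2 and compound 3 are each reported only as a limit, so the steps among them cannot be read. All three stand at the same point: the limit of > 24000 nM in this assay, at which 3 of the 3 values shown sit.

The compounds shown leave open at what concentration any of them reaches half-maximal cytotoxicity, and whether phenyl, 1,3-thiazol-2-yl and 6-methylpyridin-2-yl differ at all.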